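The source may hold more compounds than are shown below. What is called first, only, known or untested is meant among the compounds shown, and "the series" means these compounds.

In a functional assay on KB cells (Homo sapiens) for inhibition, read by MTT assay, with a stated time of 24 h, tested at 100 ug/mL (a higher number here means more inhibition of growth at the concentration tested, a lower number less inhibition of growth), compound 1 (`O=C(O)CCCCC(CCSC(=O)c1ccccc1)SC(=O)c1ccccc1`) gives 89.8% of growth inhibition. In this assay, within the data shown here, compound 2 (`O=C(CCCCC(CCSC(=O)c1ccccc1)SC(=O)c1ccccc1)Nc1cccc(Cl)c1`) is reported as "not active" (no number reported) and carries no number, so it has no measured position on the scale and no step can be calculated from compound 1. Compound 3 (`O=C(CCCCC(CCSC(=O)c1ccccc1)SC(=O)c1ccccc1)Nc1ccc(Cl)cc1`) has the same atoms as compound 2, joined differently (4-chlorophenyl in place of 3-chlorophenyl on an amide-type nitrogen), with 4-chlorophenyl in place of 3-chlorophenyl on an amide-type nitrogen. Among the measured compounds shown here, no measured pair in this small set shows what such a move does, so the expectation is necessarily loose. For the measured compounds named here, compound 2, reported as "not active" (no number reported) in this assay, is the closest reference, and little or no step from it is expected. Any step that does appear can only be upward, and compound 3 may well also be reported without a number. Recovery of the level of compound 1 is not expected, though it cannot be excluded. In this assay the growth inhibition of compound 3 is estimated at 20% (from 0% to 60%).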

Compound 3, percent growth inhibition at one concentration: 5.78%
The estimate for compound 3 lay 14.2 percentage points above the measured number; low and high end bracket the measured number.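

In this assay, among these compounds, the first readable step in this set is a number 84 percentage points lower from compound 1 to compound 3 (beyond the scatter), with (4-chlorophenyl)amino in place of hydroxy on a carbonyl carbon, so replacing the hydroxy at this position with this group is tied to a large loss of growth inhibition. Unlike compound 2, compound 3 carries a number, 5.78%, but the step between these two compounds cannot be read, and the set therefore does not show what moving from 3-chlorophenyl to 4-chlorophenyl does. No measurement available here bears on why growth inhibition falls with this change.

The compounds shown leave open whether the loss follows from the amide link itself or from the chlorophenyl ring it carries, a question that a plain phenylamino group, an unsubstituted amino group or a methoxy group on the same carbonyl carbon would help to settle. They also leave open whether a longer chain between the carbonyl carbon and the rest of the core of compound 1 would change the outcome of this replacement.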